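Sulfonyl aryl variation on the dimethylaminophenyl pyrazoline series

The source may hold more compounds than are shown below. What is called first, only, known or untested is meant among the compounds shown, and "the series" means these compounds.

Measured compounds:
Compound 1 `Cc1ccc(S(=O)(=O)N2N=C(c3ccc(-n4cncn4)cc3)CC2c2ccc(N(C)C)cc2)cc1` gives 20% in a functional assay on NCI-H1975 cells (Homo sapiens) for inhibition, read by sulforhodamine B assay, tested at 10 uM; a lower number here means less inhibition, a higher number more inhibition at the concentration tested (going by the name of the read-out).
Compound 2 `CN(C)c1ccc(C2CC(c3ccc(-n4cncn4)cc3)=NN2S(=O)(=O)c2ccc(C#N)cc2)cc1` gives 22.6% in this assay.
Compound 3 `Cc1ccc(S(=O)(=O)N2N=C(c3ccc(-n4ccnc4)cc3)CC2c2ccc(N(C)C)cc2)cc1` gives 50.5% in this assay.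

Compound 4 `CN(C)c1ccc(C2CC(c3ccc(-n4ccnc4)cc3)=NN2S(=O)(=O)c2ccc(C#N)cc2)cc1` has not been measured in this assay. It differs from compound 3 by cyano in place of methyl on an aromatic carbon. The same change, at the same place, is made from compound 1 to compound 2, where it gives a number 2.6 percentage points higher from compound 1 to compound 2 (within the scatter), the change being (cyano in place of methyl on an aromatic carbon). The cores of compound 1 and compound 3 differ by 1H-imidazol-1-yl in place of 1H-1,2,4-triazol-1-yl on an aromatic carbon, and that step reads a number 30.5 percentage points higher from compound 1 to compound 3 (beyond the scatter). Compound 3 stands highest of the three measured compounds, both other values lying beyond the scatter below it. Among the compounds with values here, the step from compound 3 to compound 4 is expected to be small, a number 2.5 percentage points higher from compound 3 to compound 4 (within the scatter), because a number 2.6 percentage points higher from compound 1 to compound 2 (within the scatter) is the only measured instance of this change and lies within the scatter. Compound 4 is therefore estimated at 53%, within a range from 38% to 68%.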

Compound 4, a percentage reported as inhibition, at one concentration (the size of the read-out at that concentration, not a potency): 0.7%
The estimate for compound 4 lay 52.3 percentage points above the measured number, outside the stated range (below it).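

In this assay, the change from methyl to cyano does not carry over from the core of compound 1 to the core of compound 3, where it gives a number 49.8 percentage points lower from compound 3 to compound 4 (beyond the scatter): the same change on two cores in this assay, a number 2.6 percentage points higher (within the scatter) from compound 1 to compound 2 and a number 49.8 percentage points lower (beyond the scatter) from compound 3 to compound 4, 52.4 percentage points apart, beyond the scatter of two such steps. The change from 1H-1,2,4-triazol-1-yl to 1H-imidazol-1-yl likewise depends on the sulfonyl aryl group, giving a number 21.9 percentage points lower from compound 2 to compound 4 (beyond the scatter): the same change on two cores in this assay, a number 30.5 percentage points higher (beyond the scatter) from compound 1 to compound 3 and a number 21.9 percentage points lower (beyond the scatter) from compound 2 to compound 4, 52.4 percentage points apart, beyond the scatter of two such steps. The two places therefore do not add independently across these four compounds, so neither step can be carried alone to a new core, but the data do not show the reason or how far this extends beyond these compounds.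

Still open, as far as these compounds go, is whether other groups in place of the methyl, such as an amine or a carboxylic acid, would also behave differently on the two cores.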